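The compounds below may be only part of what the source reports. "The series", "measured", "known", "first", "only" and "open" are said of these compounds alone.

Compound 1 `COc1ccc(C(=O)/C=C/c2ccc(OCc3cn(Cc4ccccc4)nn3)cc2)cc1` gives 70% in a functional assay on MCF7 cells (Homo sapiens) for inhibition, read by MTT assay, with a stated time of 48 h, tested at 10 uM; a higher number here means more inhibition of growth at the concentration tested, a lower number less inhibition of growth. Compound 2 `COc1ccc(C(=O)/C=C/c2ccc(OCc3cn(Cc4ccccc4Br)nn3)cc2)cc1` gives 60% in this assay, and compound 3 `COc1ccc(C(=O)/C=C/c2ccc(OCc3cn(Cc4ccc(Br)cc4)nn3)cc2)cc1` gives 53% in this assay. Among these three, compound 3 carries the lowest number, although the step of a number 7 percentage points lower from compound 2 to compound 3 (within the scatter) is within the scatter; only the step of a number 17 percentage points lower from compound 1 to compound 3 (beyond the scatter) lies beyond it, and the step of a number 10 percentage points lower from compound 1 to compound 2 (within the scatter) is again within the scatter.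

Compound 4 `COc1ccc(C(=O)/C=C/c2ccc(OCc3cn(Cc4cccc(F)c4)nn3)cc2)cc1` has not yet been measured in this assay. It differs from compound 3 by 3-fluorophenyl in place of 4-bromophenyl on a saturated chain carbon bound to an aromatic nitrogen. Among the measured compounds shown here, no measured step exchanges one halogen for another, so the nearest guides are the two halogen steps already seen: adding a bromine gave a number 10 percentage points lower from compound 1 to compound 2 (within the scatter) and a number 17 percentage points lower from compound 1 to compound 3 (beyond the scatter), and moving that bromine gave a number 7 percentage points lower from compound 2 to compound 3 (within the scatter). All of these were small, and the one beyond the scatter was only modest. The substituted benzyl groups on compounds 1, 2 and 3 thus span a narrow band of growth inhibition.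

Compound 4 is therefore expected to stay close to compound 3, with a step of a number 5 percentage points higher from compound 3 to compound 4 (within the scatter) that should not exceed the scatter. The estimate for compound 4 in this assay is 58%, with a likely range from 45% to 72%.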

Compound 4, percent growth inhibition at one concentration: 41%
For compound 4 the middle estimate is 17 percentage points above the measured one; measured number outside the range, below it.
By their numbers in this assay, from the lowest: compound 4; then compounds 3, 2 and 1 (each within the scatter of the next, the first and the last beyond it).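

In this assay the exchange of 4-bromobenzyl for 3-fluorobenzyl gives a number 12 percentage points lower from compound 3 to compound 4 (beyond the scatter), so a swap among substituted phenyl groups on this saturated chain carbon bound to an aromatic nitrogen can move the number beyond the scatter, which the shift of bromine between compound 2 and compound 3 did not do. The 3-fluorophenyl group also stands clear of the 2-bromophenyl group, with a number 19 percentage points lower from compound 2 to compound 4 (beyond the scatter), and of the plain phenyl group, with a number 29 percentage points lower from compound 1 to compound 4 (beyond the scatter), so this position no longer looks like the narrow band that the first three compounds suggested, and compound 4 now has the lowest number of the four. Nothing at hand accounts for this drop.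

The compounds shown leave open whether the lower number goes with the fluorine itself or with where it sits, as no bromine and fluorine here occupy the same place on the phenyl group. Also open, from the compounds shown here alone, is how an amine or a carboxylic acid on that phenyl group, or a longer chain in place of the single saturated carbon, would read in this assay.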